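Replacing 2,4-dihydroxyphenyl with 2-methoxyphenyl

The source may hold more compounds than are shown below. What is called first, only, known or untested is meant among the compounds shown, and "the series" means these compounds.

In a functional assay on DU-145 cells (Homo sapiens) for inhibition, read by trypan blue exclusion, with a stated time of 96 h (on this read-out lower numbers stand for stronger inhibition of growth and higher numbers for weaker inhibition of growth), compound 1 `Cc1ccsc1/C=C(/SCc1ccc(Cl)cc1)C(=O)c1ccc(Cl)cc1` gives 50000 nM and compound 2 `O=C(/C(=C\c1ccc(O)cc1O)SCc1ccc(Cl)cc1)c1ccc(Cl)cc1` gives 50000 nM as well, so compound 2 stands level with compound 1 at the digits shown. Compound 3 `COc1ccccc1/C=C(/SCc1ccc(Cl)cc1)C(=O)c1ccc(Cl)cc1` has 2-methoxyphenyl in place of 2,4-dihydroxyphenyl on a double-bonded chain carbon bound to a double-bonded chain carbon, a change counted as 2-methoxyphenyl in place of 2,4-dihydroxyphenyl on a double-bonded chain carbon bound to a double-bonded chain carbon in the structures. Among the compounds with values here, the only measured step at this place showed no change at the digits printed from compound 1 to compound 2 (within the scatter) when 2,4-dihydroxyphenyl replaced 3-methylthiophen-2-yl. Within the data shown here, that single step is thin evidence, and no measured compound carries 2-methoxyphenyl. The expected result in this assay is a 1.3-fold lower number from compound 2 to compound 3 (0.10 log units; within the scatter) and so no step beyond the scatter, with a slight lean towards stronger inhibition. The estimate for compound 3 is 40000 nM with an expected range from 10000 nM to 70000 nM in a repeated measurement.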

Compound 3, concentration for 50% growth inhibition: 1000 nM
For compound 3 the middle estimate is 40-fold (1.60 log units) above the measured one, outside the stated range (below it).
By their numbers in this assay, from the lowest: compound 3; then compounds 1 and 2 (each within the scatter of the next).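

In this assay the group on a double-bonded chain carbon bound to a double-bonded chain carbon proves able to move the result: 2-methoxyphenyl in place of 2,4-dihydroxyphenyl gives a 50-fold lower number from compound 2 to compound 3 (1.70 log units; beyond the scatter) and 2-methoxyphenyl in place of 3-methylthiophen-2-yl gives a 50-fold lower number from compound 1 to compound 3 (1.70 log units; beyond the scatter) in the same assay. The earlier pair had shown no change at this place, so compound 3 is the first sign that this position responds to the group it carries. No measurement at hand bears on what lies behind this step.

The change from compound 2 to compound 3 removes two hydroxyl groups and brings in a methoxy group at once, so the compounds shown cannot separate these two changes. From the compounds shown here alone, whether 2-hydroxyphenyl, 2-ethoxyphenyl or 2-aminophenyl would give a similar number also stays open.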